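Replacing the side chain of compound 3

This account rests on a few compounds, and the source may have more. Where it says the series, first, only, none or still open, it means among the compounds named here.

Of the compounds shown here, three sharing one core have been tested in a functional assay on A549 cells (Homo sapiens) for cytotoxicity, read by MTT assay; on this read-out higher numbers stand for weaker inhibition and lower numbers for stronger inhibition. Compound 1 `COc1ccc(-c2oc3c(CC=C(C)C)c(OCCOC(=O)CCC(=O)O)cc(O)c3c(=O)c2OCCOC(=O)CCC(=O)O)cc1` reads > 100000 nM, which is a limit and not a number. Compound 2 `COc1ccc(-c2oc3c(CC=C(C)C)c(OC(C(=O)O)C(=O)O)cc(O)c3c(=O)c2OC(C(=O)O)C(=O)O)cc1` reads > 100000 nM, again a limit. Going by the values given here, compound 3 `CCOC(=O)C(C)Oc1cc(O)c2c(=O)c(O)c(-c3ccc(OC)cc3)oc2c1CC=C(C)C` gives 26500 nM, the only true number among the three.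

Compound 4 `COc1ccc(-c2oc3c(CC=C(C)C)c(OC/C=C/C(=O)O)cc(O)c3c(=O)c2O)cc1` has not yet been measured. It carries 3-carboxyprop-2-en-1-yl in place of the 1-(ethoxycarbonyl)ethyl of compound 3, on an oxygen on an aromatic ring (3-carboxyprop-2-en-1-yl in place of 1-(ethoxycarbonyl)ethyl on an oxygen on an aromatic ring). Among the compounds with values here, no measured pair shows this change directly, so any forecast rests on thin ground. Compound 1 and compound 2, which also end in carboxy groups, share one reading, (the limit of > 100000 nM in this assay, at which 2 of the 3 values shown sit). On that basis, a modest move toward weaker inhibition is expected in this assay, an estimated 2.3-fold higher number from compound 3 to compound 4 (0.35 log units; beyond the scatter). For compound 4 the estimated value is 60000 nM, with an expected range of 22000 nM to 100000 nM.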

Compound 4, half-maximal inhibitory concentration: 22900 nM
For compound 4 the middle estimate is 2.6-fold (0.42 log units) above the measured one, within the range that was stated.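

In this assay, 3-carboxyprop-2-en-1-yl in place of 1-(ethoxycarbonyl)ethyl on this oxygen on an aromatic ring gives a 1.2-fold lower number from compound 3 to compound 4 (0.06 log units; within the scatter), so the two side chains cannot be told apart on this read-out. Going by these compounds alone, this is the first direct reading of a change at this position, and it shows that a chain ending in a carboxy group can stand on this oxygen and still give a true number. Compound 4 does not join the values that are only a limit: the limit of > 100000 nM in this assay, at which 2 of the 4 values shown sit.

From the compounds shown here alone, it remains open how an amine or a longer chain ending in a carboxylic acid would read on this oxygen. Also open, going by these compounds, is how the ethyl ester of the chain in compound 4, or the same chain without its double bond, would compare.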